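The compounds below may be only part of what the source reports. "The series", "measured", "known", "first", "only" and "open" are said of these compounds alone.

Measured in a functional assay on NCI-H146 cells (Homo sapiens) for inhibition, read by WST assay, with a stated time of 4 days; on this read-out lower numbers stand for stronger inhibition and higher numbers for weaker inhibition:
- compound 1 `Cc1c(C(=O)O)c(-c2cccc(N3CCN(c4ccc(NS(=O)(=O)c5ccc(N[C@H](CCN6CC(O)C6)CSc6ccccc6)c(S(=O)(=O)C(F)(F)F)c5)cc4)CC3)c2)c(-c2ccc(Cl)cc2)n1C`: 241 nM
- compound 2 `Cc1c(C(=O)O)c(-c2cccc(N3CCN(c4ccc(NS(=O)(=O)c5ccc(N[C@H](CCN6CCCC6)CSc6ccccc6)c(S(=O)(=O)C(F)(F)F)c5)cc4)CC3)c2)c(-c2ccc(Cl)cc2)n1C`: 87 nM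
- compound 3 `Cc1c(C(=O)O)c(-c2cccc(N3CCN(c4ccc(NS(=O)(=O)c5ccc(N[C@H](CCN6CCC(C)(O)CC6)CSc6ccccc6)c(S(=O)(=O)C(F)(F)F)c5)cc4)CC3)c2)c(-c2ccc(Cl)cc2)n1C`: 171 nM

Compound 2 gives the lowest number of the three; against compound 3 the gap is within the scatter, against compound 1 it is beyond it. Going by the values given here, the one directly relevant step is a 2.8-fold lower number from compound 1 to compound 2 (0.44 log units; beyond the scatter). Compound 4 `Cc1c(C(=O)O)c(-c2cccc(N3CCN(c4ccc(NS(=O)(=O)c5ccc(N[C@H](CCN6CCC6)CSc6ccccc6)c(S(=O)(=O)C(F)(F)F)c5)cc4)CC3)c2)c(-c2ccc(Cl)cc2)n1C` carries the change (azetidin-1-yl in place of pyrrolidin-1-yl on a saturated chain carbon, three bonds along the chain from a nitrogen on an aromatic ring). Among the compounds with values here, this reverses part of that step, the ring type, while the hydroxyl group of compound 1 stays absent, so the only guide is that a ring of the azetidine kind, with a hydroxyl, gave the highest number of the series. A modest move to a higher number is expected, probably within the scatter, as a 1.6-fold higher number from compound 2 to compound 4 (0.21 log units; within the scatter). Compound 4 is estimated at 140 nM, between 70 nM and 300 nM.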

Compound 4, half-maximal inhibitory concentration: 86 nM
Compound 4: the middle estimate sits 1.6-fold (0.21 log units) above what was measured, within the range that was stated.
By their numbers in this assay, from the lowest: compounds 4, 2, 3 and 1 (each within the scatter of the next, the first and the last beyond it).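

In this assay, the size of the ring at this position shows no effect: azetidin-1-yl and pyrrolidin-1-yl stay within the scatter of each other (a 1.0-fold lower number from compound 2 to compound 4 (0.01 log units; within the scatter)). The step beyond the scatter appears with hydrogen in place of hydroxy on a saturated ring carbon (a 2.8-fold lower number from compound 1 to compound 4 (0.45 log units; beyond the scatter)), so the earlier gap between compound 1 and compound 2 goes with the hydroxy group, not the ring size. No measurement offers an explanation for this.

Open, on these data alone, is whether the same holds on larger rings, which a plain piperidin-1-yl group would test against compound 3. Also open, as far as these compounds go, is how an open-chain dimethylamino group would read at this position.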